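From 4-methylphenyl to 4-cyanophenyl: working notes

This account rests on a few compounds, and the source may have more. Where it says the series, first, only, none or still open, it means among the compounds named here.

For the measured compounds named here, in a functional assay on A549 cells (Homo sapiens) for inhibition, read by MTT assay, with a stated time of 48 h (a lower number here means a stronger inhibitor, a higher number a weaker inhibitor), compound 1 `Cc1ccc(-c2nc3ccccn3c2Sc2ccccc2)cc1` gives 94300 nM, the highest of the three numbers so far. Compound 2 `c1ccc(Sc2c(-c3cccc4ccccc34)nc3ccccn23)cc1` gives 17900 nM and compound 3 `Cc1ccc(-c2nc3ccc(C)cn3c2Sc2ccccc2)cc1` gives 23800 nM.

The next change leads to compound 4 `N#Cc1ccc(-c2nc3ccccn3c2Sc2ccccc2)cc1`: cyano in place of methyl on an aromatic carbon, para to a large group. Going by the values given here, only one measured step bears on this, and only indirectly: a 4.0-fold lower number from compound 1 to compound 3 (0.60 log units; beyond the scatter), where methyl replaces hydrogen at a different place. Among the compounds with values here, no measured step alters the methyl of compound 1 itself, so the direction remains uncertain. A modest move to a lower number is expected in this assay. The expected change is a 2.1-fold lower number from compound 1 to compound 4 (0.32 log units; beyond the scatter). For compound 4 the estimated value is 45000 nM, with an expected range of 14000 nM to 130000 nM.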

Compound 4, half-maximal inhibitory concentration: 35200 nM
Compound 4: middle estimate off by 1.3-fold (0.11 log units), on the high side, within the range that was stated.
By their numbers in this assay, from the lowest: compounds 2, 3 and 4 (each within the scatter of the next); then compound 1.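

The position para to a large group on the aryl ring now has its first measured step: in this assay, the change from 4-methylphenyl to 4-cyanophenyl gives a 2.7-fold lower number from compound 1 to compound 4 (0.43 log units; beyond the scatter). The methyl of compound 1 is therefore not required at this position, and a group with a hydrogen-bond acceptor is tolerated in its place. No measured data on hand account for this step.

As far as these compounds go, whether the shift follows from the arrival of the nitrile or from the loss of the methyl remains open. An amine or a carboxylic acid at the same position would test how far the trend extends.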